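From trifluoromethoxy to ethoxy on the shared core

A few compounds are considered here, and "the series" means these few. Any claim that something is new, unique, unknown or untested is made for them only; others in the source may bear on it.

Measured in a functional assay on K562 cells (Homo sapiens) for antiproliferative activity, read by MTT assay, with a stated time of 72 h; on this read-out higher numbers stand for weaker inhibition and lower numbers for stronger inhibition:
- compound 1 `COc1ccc(-c2ncnn2-c2cc(OC)c(OC)c(OC)c2)cc1` gives 950 nM
- compound 2 `CCOc1ccc(-c2ncnn2-c2cc(OC)c(OC)c(OC)c2)cc1Cl` gives 20 nM
- compound 3 `COc1cc(-n2ncnc2-c2ccc(OC(F)(F)F)cc2)cc(OC)c1OC` gives > 10000 nM (a limit of the assay)

Compound 3 sits at the limit of > 10000 nM in this assay, at which 1 of the 3 values shown sits, here, so it has a limit and not a number. Compound 4 `CCOc1ccc(-c2ncnn2-c2cc(OC)c(OC)c(OC)c2)cc1` differs from it by one change, ethyl in place of trifluoromethyl on an oxygen on an aromatic ring. Among the compounds with values here, one measured step bears on this: an at least 10-fold higher number from compound 1 to compound 3 (1.02 log units; beyond the scatter) (large and beyond the scatter) with trifluoromethyl in place of methyl on that oxygen. Losing trifluoromethyl is therefore expected to bring a large step to a lower number in this assay for compound 4. Compound 1, with methyl there, gives 950 nM and compound 2, an ethoxy compound that also has a chlorine, gives 20 nM in the same assay. The expected size is an at least 33-fold lower number from compound 3 to compound 4 (1.52 log units; beyond the scatter) as an estimate only. For compound 4 the estimated value is 300 nM with an expected range from 50 nM to 1800 nM in this assay.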

Compound 4, half-maximal inhibitory concentration: 20 nM
Beside the measured number, compound 4's estimate is 15-fold (1.18 log units) above it; the measured number lies below the stated range.
By their numbers in this assay, from the lowest: compounds 2 and 4 (each within the scatter of the next); then compound 1. At a limit, above all of these: compound 3.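

In this assay ethyl on this oxygen gives a lower number than methyl with nothing else changed (a 48-fold lower number from compound 1 to compound 4 (1.68 log units; beyond the scatter)). Taking the chlorine off compound 2 leaves the number where it was (no change at the digits printed from compound 2 to compound 4 (within the scatter)), so among these compounds the low number goes with the ethoxy group and needs no chlorine. The change from trifluoromethoxy to ethoxy spans a very wide gap (an at least 500-fold lower number from compound 3 to compound 4 (2.69 log units; beyond the scatter)), and compound 3 has a limit, not a number: the limit of > 10000 nM in this assay, at which 1 of the 4 values shown sits.

On these data alone, what a longer chain such as propyl, or a small ring such as cyclopropyl, would give on this oxygen remains open.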